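A few compounds are considered here, and "the series" means these few. Any claim that something is new, unique, unknown or untested is made for them only; others in the source may bear on it.

Of the compounds shown here, three built on a shared core have been tested in a functional assay on MCF7 cells (Homo sapiens) for cytotoxicity, read by MTT assay, with a stated time of 72 h, tested at 1 uM; on this read-out lower numbers stand for less inhibition of growth and higher numbers for more inhibition of growth at the one concentration tested. Compound 1 `N/C(=N\NC(=S)N1CCOCC1)c1ccccn1` gives 14.7% in this assay. Compound 2 `Cc1cccc(/C(N)=N/NC(=S)N2CCOCC2)n1`, which carries a methyl in place of hydrogen on an aromatic carbon, gives 11.7%; the step of a number 3 percentage points lower from compound 1 to compound 2 (within the scatter) is within the scatter, so the two numbers cannot be told apart. Compound 3 `N/C(=N\NC(=S)N1CCSCC1)c1ccc(F)cn1` gives 30.6%, and it differs from compound 1 in two places at once, so its higher number cannot be traced to either change on its own. Compound 2 thus sits at the low end of the three numbers, indistinguishable from compound 1, with compound 3 beyond the scatter above it.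

Compound 4 `Cc1cccc(/C(N)=N/NC(=S)N2CCCC2)n1` has not yet been measured. It differs from compound 2 by pyrrolidin-1-yl in place of morpholin-4-yl on a thiocarbonyl carbon. For the measured compounds named here, no measured step changes the ring on the thiocarbonyl carbon alone: the only single-change step is the methyl step, and compound 3 carries a different ring together with a fluorine. There is therefore no basis for expecting a step beyond the scatter in either direction. Compound 4 is expected to give about 15%, within a range of 3% to 35%. The step of a number 3.3 percentage points higher from compound 2 to compound 4 (within the scatter) is accordingly expected to stay within the scatter.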

Compound 4, percent growth inhibition at one concentration: 17.4%
Compound 4: middle estimate off by 2.4 percentage points, on the low side, within the range that was stated.
By their numbers in this assay, from the lowest: compounds 2, 1 and 4 (each within the scatter of the next); then compound 3.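

For the compounds shown here, this is the first step that changes only the ring on the thiocarbonyl carbon, with the methyl-bearing core held fixed. In this assay the change from morpholin-4-yl to pyrrolidin-1-yl gives a number 5.7 percentage points higher from compound 2 to compound 4 (within the scatter) and so leaves the two compounds indistinguishable, even though the entering ring is five-membered, has one hetero atom rather than two and has no hydrogen-bond acceptor, so at this position and this single concentration, these differences between the two rings produce no readable step. No measurement is at hand that would explain why these two rings read alike.

What the compounds shown leave open is whether any group on the thiocarbonyl carbon can move the number beyond the scatter, since only two rings have been compared on their own, and a larger ring such as piperidin-1-yl or an open-chain group such as dimethylamino could behave differently. Going by these compounds, it also remains open whether the ring carried by compound 3 would make a difference by itself, without the fluorine that comes with it.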